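Urea to amide on the shared core: expected cytotoxicity

This account rests on a few compounds, and the source may have more. Where it says the series, first, only, none or still open, it means among the compounds named here.

Compound 1 `CNC(=O)Nc1c(C)c(C(OC(C)(C)C)C(=O)O)c(-c2ccc(C)c(C)c2)c(C)c1-c1ccc(C)c(C)c1` bears a (methylcarbamoyl)amino group on the shared core. In an ADME assay on MT4 cells (Homo sapiens) for cytotoxicity, read by MTT assay, with a stated time of 4 days (a lower number here means that less compound is tolerated, a higher number that more compound is tolerated), compound 1 gives 20000 nM. Compound 2 `Cc1ccc(-c2c(C)c(-c3ccc4c(c3C)CCCO4)c(C(OC(C)(C)C)C(=O)O)c(C)c2NS(C)(=O)=O)cc1C` gives 24000 nM in this assay, a number within the usual scatter of that for compound 1, so the two cannot be ranked. Compound 3 `Cc1ccc(-c2c(C)c(-c3ccccc3)c(C(OC(C)(C)C)C(=O)O)c(C)c2NS(C)(=O)=O)cc1C` reaches only the assay limit, > 50000 nM, in this assay. Among the compounds with values here, the single measured step, an at least 2.0-fold higher number from compound 2 to compound 3 (0.31 log units; beyond the scatter), swaps a ring on an aromatic carbon, and its size rests on (the limit of > 50000 nM in this assay, at which 1 of the 3 values shown sits). Compound 4 `CCC(=O)Nc1c(C)c(C(OC(C)(C)C)C(=O)O)c(-c2ccc(C)c(C)c2)c(C)c1-c1ccc(C)c(C)c1` differs from compound 1 elsewhere: ethyl in place of methylamino on a carbonyl carbon. Within the data shown here, no measured step concerns a carbonyl carbon, so no shift beyond the scatter is expected, and the estimated change no change at the digits printed from compound 1 to compound 4 (within the scatter) reflects that. Compound 4 is expected to give about 20000 nM, between 10000 nM and 45000 nM.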

Compound 4, half-maximal cytotoxic concentration: 15000 nM
Beside the measured number, compound 4's estimate is 1.3-fold (0.12 log units) above it, and the stated range covers the measured number.
By their numbers in this assay, from the lowest: compounds 4, 1 and 2 (each within the scatter of the next). At a limit, above all of these: compound 3.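

In this assay the change on this carbonyl carbon gives a 1.3-fold lower number from compound 1 to compound 4 (0.12 log units; within the scatter) and so does not separate the two compounds, even though the hydrogen-bond donor of methylamino leaves with it. Within the data shown here, this is the first step read at this place, since the earlier step concerned a ring on an aromatic carbon. Nothing measured here gives a cause for this result.

Going by these compounds, whether a longer chain, a phenyl ring or a carboxylic acid on this carbonyl carbon would move the number beyond the scatter stays open.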